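This account rests on a few compounds, and the source may have more. Where it says the series, first, only, none or still open, it means among the compounds named here.

Measured so far:
Compound 1, `COCCNc1nc(-c2ccccc2)cc2c1c(N)nn2C`, in an assay on isolated protein for inhibition of protein kinase C zeta type (Homo sapiens), read by mobility shift assay, tested at 30 uM (a higher number here means more inhibition at the concentration tested (going by the name of the read-out), a lower number less inhibition), compound 1 gives 20%.
Compound 2, `COCCNc1nc(C)cc2nn(-c3ccccc3)c(N)c12`, in this assay compound 2 gives -123%.

Compound 2 stands at the lowest of the two numbers; its nearest neighbour is compound 1, whose number lies higher by a gap that is beyond the scatter. Going by the values given here, no single-point step between the two measured compounds is available, since they differ in more than one place, so the two values can only be set side by side.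

Compound 3, `Cc1cc2nn(-c3ccccc3)c(N)c2c(N2CCCCC2)n1`, has not yet been measured. It differs from compound 2 in one place: piperidin-1-yl in place of (2-methoxyethyl)amino on an aromatic carbon. Whether this exchange moves the number is not shown by any measured pair here. Compound 3 is therefore expected to stay in the region of compound 2, with a step of a number 63 percentage points higher from compound 2 to compound 3 (beyond the scatter) in this assay that is expected to be modest and of uncertain direction. The estimated value for compound 3 in this assay is -60%, with a range from -160% to 30%.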

Compound 3, a percentage reported as inhibition, at one concentration (the size of the read-out at that concentration, not a potency): -96%
For compound 3 the middle estimate is 36 percentage points above the measured one; low and high end bracket the measured number.
By their numbers in this assay, from the lowest: compound 2; then compound 3; then compound 1.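

Going by these compounds alone, the first single-place pair shows that the aromatic carbon next to the ring nitrogen is sensitive to its substituent: replacing the open (2-methoxyethyl)amino chain with the piperidin-1-yl ring gives a number 27 percentage points higher from compound 2 to compound 3 (beyond the scatter) in this assay. The change does not bring the read-out to positive inhibition, as compound 3 still gives -96%, so on this pair the exchange shifts a negative number without reversing its sign. The exchange alters the ring content, the heavy-atom count and the hydrogen-bond donor and acceptor counts together, so this one step cannot assign the shift to any one of these differences, and no supporting evidence bears on the result.

The compounds shown leave open how a morpholin-4-yl ring, which would keep a ring at this carbon while restoring an oxygen, or a small dimethylamino group would read at the same place. They also leave open whether the same exchange would give a similar step on a core carrying a different group at the other positions, such as the core of compound 1.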